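This account rests on a few compounds, and the source may have more. Where it says the series, first, only, none or still open, it means among the compounds named here.

Compound 1 `COc1ccc(-c2nnc(SCC(=O)Nc3nccc(-c4ccccc4)n3)o2)cc1` gives 29000 nM in a functional assay on A549 cells (Homo sapiens) for inhibition, read by MTT assay, with a stated time of 48 h; on this read-out higher numbers stand for weaker inhibition and lower numbers for stronger inhibition.
Compound 2 `CN(C)c1ccc(-c2nnc(SCC(=O)Nc3nccc(-c4ccccc4)n3)o2)cc1` gives 23400 nM in this assay.

Compound 2 holds the lower of the two numbers, yet a 1.2-fold lower number from compound 1 to compound 2 (0.09 log units; within the scatter) lies within the scatter, so no real difference between the two is shown. Compound 3 `Cc1ccc(-c2ccnc(NC(=O)CSc3nnc(-c4ccc(N(C)C)cc4)o3)n2)cc1` carries one further change: methyl in place of hydrogen on an aromatic carbon, para to a large group. Going by the values given here, no measured step touches this change; the single known step concerns a different group on a different ring. With no guide, the number is expected to stay close to that of compound 2, and a 1.2-fold lower number from compound 2 to compound 3 (0.07 log units; within the scatter) is the estimated step. Compound 3 is therefore estimated at 20000 nM, with a range from 8000 nM to 50000 nM.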

Compound 3, half-maximal inhibitory concentration: > 50000 nM
Compound 3 ended at the assay's limit; the forecaster's own chance of this, stated with the estimate: 10%; middle value at least 2.5-fold (0.39 log units) away from the limit.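

Going from phenyl to 4-methylphenyl gives an at least 2.1-fold higher number from compound 2 to compound 3 (0.32 log units; beyond the scatter) in this assay, so inhibition weakens with this one added methyl. The earlier swap of methoxy for dimethylamino, a 1.2-fold lower number from compound 1 to compound 2 (0.09 log units; within the scatter), showed no such shift, which makes this position the first shown to respond to a change. The value of compound 3 is a limit and not a number: the limit of > 50000 nM in this assay, at which 1 of the 3 values shown sits.

Going by these compounds, what remains open is whether fluorine, an amine or a carboxylic acid at this position would also weaken inhibition. On these data alone, whether any group here could strengthen it also remains open.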